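From one hydroxyphenyl to a dibromo hydroxyphenyl

This account rests on a few compounds, and the source may have more. Where it says the series, first, only, none or still open, it means among the compounds named here.

Measured so far in a functional assay on MCF7 cells (Homo sapiens) for inhibition, read by MTT assay, with a stated time of 48 h; a lower number here means a stronger inhibitor, a higher number a weaker inhibitor:
compound 1 `Clc1ccc(CSc2nnc(-c3ccncc3)n2-c2ccccc2)cc1` gives 13300 nM
compound 2 `O=[N+]([O-])c1cccc(CSc2nnc(-c3ccncc3)n2-c2ccccc2)c1` gives 18300 nM
compound 3 `O=C(CSc1nnc(-c2ccncc2)n1-c1ccccc1)N/N=C/c1ccc(O)cc1` gives > 50000 nM, a limit of the assay and not a number

Compound 3 therefore stands at the edge of what this assay reports, as the limit of > 50000 nM in this assay, at which 1 of the 3 values shown sits, shows. Within the data shown here, the only measured step, a 1.4-fold higher number from compound 1 to compound 2 (0.14 log units; within the scatter), swaps the group on a saturated chain carbon bound to a sulfur and stays within the scatter; it does not touch the part of compound 3 altered here. Compound 4 `O=C(CSc1nnc(-c2ccncc2)n1-c1ccccc1)N/N=C/c1cc(Br)cc(Br)c1O` arises through (3,5-dibromo-2-hydroxyphenyl in place of 4-hydroxyphenyl on a carbon with a double bond to nitrogen). Among the measured compounds shown here, no measured step bears on this position, so the data give no direction. Compound 4 is expected to lie near 30000 nM, between 8000 nM and 60000 nM. The step of an at least 1.6-fold lower number from compound 3 to compound 4 (0.22 log units; that floor lies within the scatter) is expected to be modest, with a real chance that the assay again reports only a limit.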

Compound 4, half-maximal inhibitory concentration: 8440 nM
For compound 4 the middle estimate is 3.6-fold (0.55 log units) above the measured one, and the stated range covers the measured number.
By their numbers in this assay, from the lowest: compounds 4, 1 and 2 (each within the scatter of the next, the first and the last beyond it). At a limit, above all of these: compound 3.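

On a carbon with a double bond to nitrogen, the group does matter in this assay: 3,5-dibromo-2-hydroxyphenyl in place of 4-hydroxyphenyl brings an at least 5.9-fold lower number from compound 3 to compound 4 (0.77 log units; beyond the scatter). Among these compounds, the one earlier step, on a saturated chain carbon bound to a sulfur, stayed within the scatter. The full size of this new step cannot be read, because compound 3 sits at a limit of the assay and not at a number: the limit of > 50000 nM in this assay, at which 1 of the 4 values shown sits.

The compounds shown leave open whether the two bromine atoms or the changed place of the hydroxy group carries the step. On these data alone, whether a single bromine, an amine or a carboxylic acid on this ring would do the same also remains open.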